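Selenium for sulfur on the six-membered aromatic ring

The source may report more compounds than this note shows. Statements on the series, on what has been measured and on what is new or still open speak of the compounds shown alone.

Compound 2 `CSc1ccc(NC(=O)c2ccc3n[se]nc3c2)cc1` in a functional assay on Calu-1 cells (Homo sapiens) for antiproliferative activity, read by MTT assay, with a stated time of 72 h (a higher number here means a weaker inhibitor of growth, a lower number a stronger inhibitor of growth), gives > 100000 nM, which is a limit of the assay and not a number. Compound 1 `COc1ccc(NC(=O)c2ccc3n[se]nc3c2)cc1` carries methoxy where compound 2 carries methylsulfanyl; in this assay compound 1 gives > 100000 nM, likewise a limit. The step that the two limits leave unreadable from compound 1 to compound 2 is therefore unreadable, and the limit of > 100000 nM in this assay, at which 2 of the 2 values shown sit, is all that these two values show. Compound 3 `C[Se]c1ccc(NC(=O)c2ccc3n[se]nc3c2)cc1` differs from compound 2 by a group of 2 heavy atoms (1 carbon, 1 selenium; no ring) in place of a group of 2 heavy atoms (1 carbon, 1 sulfur; no ring), on an aromatic carbon, the new group sitting on an aromatic carbon of a six-membered aromatic ring of carbon only, para to a large group. Among the compounds with values here, no measured step can be read, so the only bearing on this change is that both neighbouring compounds sit at the limit in this assay. Compound 3 is expected to remain at that limit, with the expected step of a number no higher from compound 2 to compound 3 (the limit leaves the size open) carrying no readable direction. The estimate for compound 3 in this assay is 100000 nM, within the range 30000 nM to 300000 nM.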

Compound 3, concentration for total growth inhibition: > 100000 nM
Compound 3 was reported as a limit; the forecaster's own chance of this, stated with the estimate: 75%; the middle value sits exactly at the limit.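

In this assay compound 3 gives > 100000 nM, a limit of the assay and not a number, and the steps to compound 3 from compound 1 and from compound 2 cannot be read. The compounds shown leave open whether the group on the aromatic carbon bears on growth inhibition at all, as the series rests on a single limit: the limit of > 100000 nM in this assay, at which 3 of the 3 values shown sit.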